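A few compounds are considered here, and "the series" means these few. Any claim that something is new, unique, unknown or untested is made for them only; others in the source may bear on it.

Working notes on the series.

In a functional assay on DU-145 cells (Homo sapiens) for inhibition, read by trypan blue exclusion, with a stated time of 96 h (on this read-out higher numbers stand for weaker inhibition of growth and lower numbers for stronger inhibition of growth), compound 1 `O=C(/C(=C\c1ccc(Cl)cc1Cl)Sc1ccc(Br)cc1)c1ccc(Br)cc1` gives 1000 nM and compound 2 `O=C(/C(=C\c1ccc(Br)c([N+](=O)[O-])c1)Sc1ccc(Br)cc1)c1ccc(Br)cc1` gives 1000 nM. For the measured compounds named here, compound 3 `COc1ccc(/C=C(/Sc2ccc(Br)cc2)C(=O)c2ccc(Br)cc2)c(F)c1` gives 20000 nM in this assay and stands highest of the three numbers; its nearest neighbour is compound 1, and the step of a 20-fold higher number from compound 1 to compound 3 (1.30 log units; beyond the scatter) is the only single-point change measured so far, large and beyond the scatter.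

Compound 4 `O=C(/C(=C\c1ccc(Br)cc1)Sc1ccc(Br)cc1)c1ccc(Br)cc1` is not yet measured. Relative to compound 3 the change is 4-bromophenyl in place of 2-fluoro-4-methoxyphenyl on a double-bonded chain carbon bound to a double-bonded chain carbon. This undoes the group that, in the step from compound 1 to compound 3, was accompanied by the large rise, so a fall of similar size is expected for compound 4: the estimated step of a 13-fold lower number from compound 3 to compound 4 (1.12 log units; beyond the scatter) is expected to bring it close to compound 1 and compound 2. Compound 4 is estimated at 1500 nM in this assay, with a range from 500 nM to 5000 nM.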

Compound 4, concentration for 50% growth inhibition: 1000 nM
The estimate for compound 4 lay 1.5-fold (0.18 log units) above the measured number; the range from low to high includes it.
By their numbers in this assay, from the lowest: compounds 1, 2 and 4 (each within the scatter of the next); then compound 3.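

At this place, on a double-bonded chain carbon bound to a double-bonded chain carbon, this assay gives a 20-fold lower number from compound 3 to compound 4 (1.30 log units; beyond the scatter), so the high number now stands out against two other aryl groups, not only 2,4-dichlorophenyl. Replacing 2,4-dichlorophenyl with 4-bromophenyl gives no change at the digits printed from compound 1 to compound 4 (within the scatter), and hydrogen in place of nitro on an aromatic carbon gives no change at the digits printed from compound 2 to compound 4 (within the scatter). Nothing available explains these results.

The compounds shown leave open whether the fluoro or the methoxy part of 2-fluoro-4-methoxyphenyl goes with the high number. On these data alone, how a phenyl carrying an amine or a carboxylic acid would read at this place also stays open.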